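The source may hold more compounds than are shown below. What is called first, only, known or untested is meant among the compounds shown, and "the series" means these compounds.

Measured compounds in a functional assay on FaDu cells (Homo sapiens) for cytotoxicity, read by MTT assay, with a stated time of 72 h; on this read-out higher numbers stand for lower toxicity in this test and lower numbers for higher toxicity in this test:

compound 1, `CCn1cc(C(=O)C(=O)Nc2ccnc(OC)c2)c2ccccc21`, gives 4180 nM.
compound 2, `CCn1cc(C(=O)C(=O)Nc2ccncc2)c2ccccc21`, gives > 10000 nM; that reading is a limit of the assay, not a number.
compound 3, `COc1ccc(NC(=O)C(=O)c2cn(C(C)C)c3ccccc23)cn1`, gives 85 nM.

Compound 2 and compound 1 differ by one change, (methoxy in place of hydrogen on an aromatic carbon). That change gives an at least 2.3-fold lower number from compound 2 to compound 1 (0.37 log units; beyond the scatter), with the note that the limit of > 10000 nM in this assay, at which 1 of the 3 values shown sits, is where the starting value sits, so only a lower bound of the step is known.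

Compound 3 is lower than compound 1 in this assay, and the gap is beyond the scatter; the difference between the two cores is not broken down here.

Compound 4, `COc1ccc2c(C(=O)C(=O)Nc3ccc(OC)nc3)cn(C(C)C)c2c1`, is not yet measured. It differs from compound 3 by methoxy in place of hydrogen on an aromatic carbon. Among the compounds with values here, this is the same kind of change as the one from compound 2 to compound 1, but not the same: there the methoxy entered on a six-membered aromatic ring with one nitrogen, next to the ring nitrogen and meta to a large group; here it enters on a six-membered aromatic ring of carbon only, part of a fused system of two rings, meta and para to a fused ring.

For compound 4 a step of about a 1.4-fold lower number from compound 3 to compound 4 (0.15 log units; within the scatter) is expected, resting on the direction of an at least 2.3-fold lower number from compound 2 to compound 1 (0.37 log units; beyond the scatter), tempered by the different surroundings of the change. The value for compound 4 is estimated at 60 nM, likely between 20 nM and 250 nM.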

Compound 4, concentration lethal to 50% of the cells: > 10000 nM
Compound 4 gave a limit, no number; the forecaster's own chance of this, stated with the estimate: 2%; middle value at least 160-fold (2.22 log units) away from the limit.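

Methoxy in place of hydrogen on an aromatic carbon does not carry over as one effect between these two cores in this assay: the same change on two cores in this assay, an at least 2.3-fold lower number (0.37 log units; beyond the scatter) from compound 2 to compound 1 and an at least 110-fold higher number (2.07 log units; beyond the scatter) from compound 3 to compound 4, at least 280-fold (2.44 log units) apart, beyond the scatter of two such steps. On the six-membered aromatic ring of carbon only, the change gives an at least 110-fold higher number from compound 3 to compound 4 (2.07 log units; beyond the scatter), whereas on the ring with one nitrogen it gives an at least 2.3-fold lower number from compound 2 to compound 1 (0.37 log units; beyond the scatter), so the earlier step was no guide to direction here, but with one pair per core this sets no rule for either ring and does not separate the ring that receives the methoxy from the other differences between the cores. On these data alone, compound 4 reads > 10000 nM, which is a limit of the assay, and compound 2 also sits at a limit, so both steps are known only as bounds and their true sizes remain unknown: the limit of > 10000 nM in this assay, at which 2 of the 4 values shown sit.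

The compounds shown leave open whether the large step is tied to this one place on the ring of carbon only, or whether methoxy elsewhere on that ring would give a number near that of compound 3. Also open, as far as these compounds go, is how a fluorine atom, a hydroxyl or an amine would read at the same carbon in place of the methoxy.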